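A few compounds are considered here, and "the series" means these few. Any claim that something is new, unique, unknown or untested is made for them only; others in the source may bear on it.

In an assay on isolated protein with Bile acid receptor (Homo sapiens) as the target (a lower number here means that less compound is needed, a higher number that more compound is needed for the effect), compound 1, whose structure is `COC(=O)/C=C/c1cccc(N(Cc2ccc(-c3cccc(Cl)c3)cc2)C(=O)C2CCCCC2)c1`, gives 94 nM. Compound 2, with structure `COC(=O)/C=C/c1cccc(N(Cc2ccc(-c3cccc(C)c3)cc2)C(=O)C2CCCCC2)c1`, carries the change methyl in place of chloro on an aromatic carbon and in this assay gives 109 nM; that step was a 1.2-fold higher number from compound 1 to compound 2 (0.06 log units; within the scatter). Compound 3, with structure `COC(=O)/C=C/c1cccc(N(Cc2ccc(-c3cccc(Cl)c3)cc2)C(=O)NC(C)C)c1`, differs from compound 1 by isopropylamino in place of cyclohexyl on a carbonyl carbon, and in this assay compound 3 gives 1400 nM, a step of a 15-fold higher number from compound 1 to compound 3 (1.17 log units; beyond the scatter). Compound 4, whose structure is `COC(=O)/C=C/c1cccc(N(Cc2ccc(-c3cccc(C)c3)cc2)C(=O)NC(C)C)c1`, has not been measured in this assay. It stands to compound 3 as compound 2 stands to compound 1: the change is methyl in place of chloro on an aromatic carbon, the same change made twice among these four compounds, on the same kind of place both times. Among the compounds with values here, the only guide to what it will do is the single earlier step from compound 1 to compound 2, which stayed within the scatter. On that basis the step from compound 3 to compound 4 in this assay is expected to be a 1.1-fold higher number from compound 3 to compound 4 (0.06 log units; within the scatter), resting on the value of compound 3, 1400 nM, and on the earlier step of a 1.2-fold higher number from compound 1 to compound 2 (0.06 log units; within the scatter). For compound 4 the estimate in this assay is 1600 nM, with a range from 700 nM to 3600 nM.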

Compound 4, half-maximal effective concentration: 1330 nM
Compound 4: middle estimate off by 1.2-fold (0.08 log units), on the high side; measured number inside the range.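

In this assay, methyl in place of chloro on the aromatic carbon again left the number within the scatter, a 1.1-fold lower number from compound 3 to compound 4 (0.02 log units; within the scatter), and this held on both cores: the same change on two cores in this assay, a 1.2-fold higher number (0.06 log units; within the scatter) from compound 1 to compound 2 and a 1.1-fold lower number (0.02 log units; within the scatter) from compound 3 to compound 4, 1.2-fold (0.09 log units) apart, within the scatter of two such steps. Isopropylamino in place of cyclohexyl on the carbonyl carbon gave a large step with methyl on the ring as well, a 12-fold higher number from compound 2 to compound 4 (1.09 log units; beyond the scatter), and its size carried over from the chloro compounds to the methyl compounds: the same change on two cores in this assay, a 15-fold higher number (1.17 log units; beyond the scatter) from compound 1 to compound 3 and a 12-fold higher number (1.09 log units; beyond the scatter) from compound 2 to compound 4, 1.2-fold (0.09 log units) apart, within the scatter of two such steps. Across these four compounds the two changes therefore behave as if each acts apart from the other, but this rests on a single pair of steps per change, and the agreement for the chloro-to-methyl swap only shows that a step within the scatter stayed so, not that a change with a real effect on that ring would carry over as well.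

The compounds shown leave open whether a methoxy group, a nitrile or an amine at that place on the 3-chlorophenyl ring would carry across these cores in the same way. They also leave open how a carboxylic acid in place of the methyl ester, or a longer chain in place of the isopropylamino group, would behave.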